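The compounds below may be only part of what the source reports. "The series", "measured", "known", "first", "only" and "open" are said of these compounds alone.

Measured so far:
compound 1, `CN1CCC(n2cc(S(=O)(=O)c3ccccc3Cl)c3cccnc32)C1`, 2.2 nM
compound 2, `CC(C)N1CCCC(n2cc(S(=O)(=O)C3=C(Cl)NC4SC=CN34)c3cccnc32)C1`, 1.7 nM
compound 3, `O=S(=O)(c1ccccc1Cl)c1cn(C2CCCNC2)c2ncccc12`, 3.7 nM

These three compounds were tested in an assay on HeLa cells for displacement of a labelled ligand from 5-hydroxytryptamine receptor 6 (Homo sapiens); on this read-out lower numbers stand for stronger inhibition and higher numbers for weaker inhibition. Compound 3 shows the highest number of the three. Its nearest neighbour is compound 1, and the step of a 1.7-fold higher number from compound 1 to compound 3 (0.23 log units; within the scatter) lies within the scatter. Compound 2 has a lower number than compound 3, and that gap lies beyond the scatter; compound 2 differs from compound 3 in more than one place, so only the two values themselves can be compared.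

Compound 4, `O=S(=O)(c1cc(Cl)cc(Cl)c1)c1cn(C2CCCNC2)c2ncccc12`, is the next compound to be measured. It differs from compound 3 in one place: 3,5-dichlorophenyl in place of 2-chlorophenyl on a sulfonyl sulfur. Among the compounds with values here, the only measured single-place step, from compound 1 to compound 3, concerns the group on the aromatic nitrogen, not the group on the sulfonyl sulfur, so no measured step bears directly on this change. The series gives no guide to how the ring on the sulfonyl sulfur may be varied. With the amine part unchanged from compound 3, compound 4 is expected to stay in the same region, with a modest rise in the number plausible, as estimated by a 1.6-fold higher number from compound 3 to compound 4 (0.21 log units; within the scatter). The estimate for compound 4 in this assay is 6 nM, within a range from 1.5 nM to 25 nM.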

Compound 4, inhibition constant: 6.1 nM
The estimate for compound 4 lay 1.0-fold (0.01 log units) below the measured number; the measured number falls inside the stated range.
By their numbers in this assay, from the lowest: compounds 2, 1, 3 and 4 (each within the scatter of the next, the first and the last beyond it).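

In this assay, within the data shown here, the change at this place on a sulfonyl sulfur, 3,5-dichlorophenyl in place of 2-chlorophenyl, gives a 1.6-fold higher number from compound 3 to compound 4 (0.22 log units; within the scatter) and is the only measured step that touches this ring. It shows that this ring can carry two chlorines instead of one, placed differently, with the amine part held constant and no shift beyond the usual scatter of the measurement. Because the chlorine count and the chlorine placement both differ in this one step, their separate contributions cannot be told apart, and no measured property of either group is available to account for the result.

Going by these compounds, it remains open whether a plain phenyl, a phenyl carrying a methoxy group or a ring bearing a carboxylic acid would also stay within the scatter at this place on the sulfonyl sulfur. On these data alone, it is equally open whether 3,5-dichlorophenyl would give a similar reading when paired with the 1-methylpyrrolidin-3-yl group that compound 1 carries on the aromatic nitrogen.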